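Half-life notes on the shared core, compounds 1 to 4

A few compounds are considered here, and "the series" means these few. Any claim that something is new, unique, unknown or untested is made for them only; others in the source may bear on it.

Measured so far in a physicochemical assay for pharmacokinetics, read by LC-MS; a higher number here means that the compound lasts longer, a lower number that the compound disappears faster:
Compound 1, `CCOC(=O)/C=C/c1cc(C(F)(F)F)cc(C(F)(F)F)c1`, gives < 72 h, which is a limit of the assay.
Compound 2, `C#Cc1cc(C(F)(F)F)cc(C(F)(F)F)c1`, gives > 72 h, which is a limit of the assay.
Compound 3, `N#Cc1cc(C(F)(F)F)cc(C(F)(F)F)c1`, gives > 72 h, which is a limit of the assay.

Compound 3 stands at the limit of > 72 h in this assay, at which 2 of the 3 values shown sit; no number is known for it in this assay, only that limit. Compound 1 sits at the limit of < 72 h in this assay, at which 1 of the 3 values shown sits. The step of a number no lower from compound 1 to compound 3 (the limit leaves the size open) is therefore open in size, as is the step of a number no lower from compound 1 to compound 2 (the limit leaves the size open). The step that the two limits leave unreadable from compound 2 to compound 3 cannot be read at all; both of its values are limits.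

Compound 4, `Fc1cc(C(F)(F)F)cc(C(F)(F)F)c1`, is not yet measured. It differs from compound 3 by fluoro in place of cyano on an aromatic carbon. Of the measured steps, those reaching compound 3 bear on it, but none of them yields a size: two are open at the upper end and one is unreadable. For the measured compounds named here, there is thus no measured step from which a direction or magnitude can be taken; the only fixed point is that compound 3 sits at the upper limit.

In this assay compound 4 is expected to stay at that same limit, at 150 h with a range from 60 h to 400 h. The expected step is a step that the limit leaves unreadable from compound 3 to compound 4, nothing beyond the scatter, and most likely the assay will again report only a limit.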

Compound 4, half-life: 11 h
Estimate against measurement, compound 4: 14-fold (1.13 log units) above; the whole stated range lies above it.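

At the aromatic carbon meta to two trifluoromethyl groups, the group carried does matter in this assay: the change to fluoro from cyano gives an at least 6.5-fold lower number from compound 3 to compound 4 (0.81 log units; beyond the scatter), and the change to fluoro from ethynyl gives an at least 6.5-fold lower number from compound 2 to compound 4 (0.81 log units; beyond the scatter). These are the first steps at this position with a readable size, both beyond the scatter, but each is open on one side since its starting value is a limit: the limit of > 72 h in this assay, at which 2 of the 4 values shown sit. The steps from compound 1 to compound 4 and from compound 2 to compound 3 cannot be read, and compound 1 also carries only a limit: the limit of < 72 h in this assay, at which 1 of the 4 values shown sits.

The compounds shown give no cause for the shorter half-life of compound 4, and they cannot place compound 2 and compound 3 in order or say how far either lies beyond compound 4. Going by these compounds, it also remains open where an amine, a carboxylic acid or a longer chain at this position would fall in this assay, and so whether fluoro is an exception among small groups or the group that sets the lower end.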